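From ethoxy to 4-hydroxypiperidin-1-yl on the carbonyl

The source may report more compounds than this note shows. Statements on the series, on what has been measured and on what is new or still open speak of the compounds shown alone.

Measured in a functional assay on A549 cells (Homo sapiens) for antiproliferative activity, read by sulforhodamine B assay, with a stated time of 72 h; a higher number here means a weaker inhibitor, a lower number a stronger inhibitor:
- compound 1 `CCOC(=O)c1cnc2ccc(-c3cnc(OC)c(NS(=O)(=O)c4ccc(F)cc4F)c3)cn12`: 300 nM
- compound 2 `CCOC(=O)c1cnc2ccc(-c3cnc(OC)c(NS(=O)(=O)c4ccc(F)cc4)c3)cn12`: 510 nM
- compound 3 `CCCCS(=O)(=O)Nc1cc(-c2ccc3ncc(C(=O)OCC)n3c2)cnc1OC`: 3560 nM

Compound 1 shares the low end of these numbers with compound 2. Hydrogen in place of fluoro on an aromatic carbon gives a 1.7-fold higher number from compound 1 to compound 2 (0.23 log units; within the scatter). Butyl in place of 2,4-difluorophenyl on a sulfonyl sulfur gives a 12-fold higher number from compound 1 to compound 3 (1.07 log units; beyond the scatter), and butyl in place of 4-fluorophenyl gives a 7.0-fold higher number from compound 2 to compound 3 (0.84 log units; beyond the scatter).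

Compound 4 `COc1ncc(-c2ccc3ncc(C(=O)N4CCC(O)CC4)n3c2)cc1NS(=O)(=O)c1ccc(F)cc1F` keeps the sulfonyl side of compound 1 and changes the group on a carbonyl carbon: 4-hydroxypiperidin-1-yl in place of ethoxy on a carbonyl carbon. Ethoxycarbonyl thus becomes (4-hydroxypiperidin-1-yl)carbonyl.

None of the three measured steps touches this carbonyl. Going by the values given here, they show only that a single change can be small, as in a 1.7-fold higher number from compound 1 to compound 2 (0.23 log units; within the scatter), or large, as in a 12-fold higher number from compound 1 to compound 3 (1.07 log units; beyond the scatter). They give neither a size nor a direction for the present change. The central expectation in this assay is therefore no step beyond the scatter, held with wide margins on both sides. The estimated step is a 1.2-fold higher number from compound 1 to compound 4 (0.07 log units; within the scatter). For compound 4 the expected value is 350 nM, with an estimated range of 70 nM to 1700 nM.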

Compound 4, half-maximal inhibitory concentration: 480 nM
For compound 4 the middle estimate is 1.4-fold (0.14 log units) below the measured one; measured number inside the range.
By their numbers in this assay, from the lowest: compounds 1, 4 and 2 (each within the scatter of the next); then compound 3.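

In this assay the exchange of ethoxy for 4-hydroxypiperidin-1-yl on the carbonyl carbon gives a 1.6-fold higher number from compound 1 to compound 4 (0.20 log units; within the scatter) and so stays within the scatter, although the entering group brings 7 heavy atoms in place of 3, a six-membered non-aromatic ring and a hydrogen-bond donor. Going by these compounds alone, this is the first reading at this carbonyl, and on the background of compound 1 it contrasts with the sulfonyl side, where butyl in place of 2,4-difluorophenyl gives a 12-fold higher number from compound 1 to compound 3 (1.07 log units; beyond the scatter) and lies beyond the scatter. No measurement on hand accounts for the small size of the carbonyl step.

A single exchange on a single sulfonyl background cannot show how far this carbonyl accepts other groups, and a plain piperidine without the hydroxyl, a morpholine or a free carboxylic acid would each test a different part of the change. From the compounds shown here alone, it also remains open whether the same exchange would give a step of similar size with the butyl sulfonyl group of compound 3 or the 4-fluorophenyl sulfonyl group of compound 2.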